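The source may hold more compounds than are shown below. What is called first, only, known or untested is meant among the compounds shown, and "the series" means these compounds.

The measured compounds:
Compound 1, `CC(C)(C)N(NC(=O)c1ccccc1)C(=O)c1ccccc1I`: 105 nM in an assay on cells for agonist activity at ecdysone receptor (Bombyx mori), read by a luciferase reporter, with a stated time of 24 h; on this read-out higher numbers stand for an effect only at larger amounts of compound and lower numbers for an effect already at smaller amounts.
Compound 2, `COc1cccc(C(=O)NN(C(=O)c2ccccc2Cl)C(C)(C)C)c1`: 52.5 nM in this assay.
Compound 3, `COc1cccc(C(=O)NN(C(=O)c2ccccc2Cl)C(C)(C)C)c1C`: 15.5 nM in this assay.

In this assay compound 2 stands between the other two: its number lies within the scatter of that of compound 1, while compound 3 sits beyond the scatter with the lower number. Going by the values given here, the only step in the set is the one from methyl in place of hydrogen on an aromatic carbon, a 3.4-fold lower number from compound 2 to compound 3 (0.53 log units; beyond the scatter), a modest change.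

Compound 4, `Cc1ccc(C)c(C(=O)NN(C(=O)c2ccccc2Cl)C(C)(C)C)c1`, has not yet been measured. It differs from compound 2 by 2,5-dimethylphenyl in place of 3-methoxyphenyl on a carbonyl carbon. Among the compounds with values here, this is not the same change as the one between compound 2 and compound 3: here the methoxy group leaves and two methyl groups enter on the same aromatic ring. The measured step bears on it only in part, because a 3.4-fold lower number from compound 2 to compound 3 (0.53 log units; beyond the scatter) shows that a methyl entering on this ring went with a modest lowering of the number; nothing in the set tells what the loss of the methoxy group does on its own. Compound 4 is therefore expected to give a number in this assay near or somewhat below that of compound 2, an estimated step of a 1.5-fold lower number from compound 2 to compound 4 (0.18 log units; within the scatter), with wide uncertainty. The estimate for compound 4 is 35 nM, with an expected range from 12 nM to 110 nM.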

Compound 4, half-maximal effective concentration: 1620 nM
For compound 4 the middle estimate is 46-fold (1.67 log units) below the measured one; measured number outside the range, above it.
By their numbers in this assay, from the lowest: compound 3; then compounds 2 and 1 (each within the scatter of the next); then compound 4.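

In this assay, going by these compounds alone, the group on the carbonyl carbon turns out to be far more sensitive to change than the earlier compounds showed, with 2,5-dimethylphenyl in place of 3-methoxyphenyl giving a 31-fold higher number from compound 2 to compound 4 (1.49 log units; beyond the scatter). Methyl groups on this ring therefore do not go with a lower number in every case: the lowering seen as a 3.4-fold lower number from compound 2 to compound 3 (0.53 log units; beyond the scatter) came with the methoxy group still present, and compound 4, which lacks that group, goes against any such rule. The two groups have the same count of heavy atoms and one six-membered aromatic ring each, and the counted difference is the hydrogen-bond acceptor that leaves with 3-methoxyphenyl, but no measurement here gives a reason for the size of this step.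

This single change removes the methoxy group and brings in two methyl groups at once, so the compounds shown do not separate the share of each. As far as these compounds go, it also stays open whether a hydroxyl or an ethoxy group in place of the methoxy group would keep the number near that of compound 2.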